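Working notes: chloro in place of methoxy

This account rests on a few compounds, and the source may have more. Where it says the series, first, only, none or still open, it means among the compounds named here.

- compound 1 `COc1ccc(-c2nnc(SC3=CS(=O)(=O)c4ccccc43)o2)cc1` gives 22000 nM
- compound 2 `COc1cccc(-c2nnc(SC3=CS(=O)(=O)c4ccccc43)o2)c1` gives 20000 nM

In an ADME assay on HepG2 cells (Homo sapiens) for cytotoxicity, read by fluorescence and resazurin assay, with a stated time of 24 h (on this read-out higher numbers stand for lower toxicity in this test and lower numbers for higher toxicity in this test), compound 2 stands at 20000 nM within the scatter of compound 1. Compound 3 `O=S1(=O)C=C(Sc2nnc(-c3cccc(Cl)c3)o2)c2ccccc21` differs from it by chloro in place of methoxy on an aromatic carbon, meta to a large group chloro in place of methoxy on an aromatic carbon as the counted change. Going by the values given here, the sole measured step, a 1.1-fold lower number from compound 1 to compound 2 (0.04 log units; within the scatter) in size, exchanges no methoxy for another group, so it bears only indirectly. No step beyond the scatter is therefore expected in this assay on this evidence. The expected change is a 1.1-fold lower number from compound 2 to compound 3 (0.05 log units; within the scatter) in size. Compound 3 is estimated at 18000 nM with an expected range from 7000 nM to 45000 nM for the measurement.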

Compound 3, half-maximal cytotoxic concentration: 27000 nM
Beside the measured number, compound 3's estimate is 1.5-fold (0.18 log units) below it; the measured number falls inside the stated range.
By their numbers in this assay, from the lowest: compounds 2, 1 and 3 (each within the scatter of the next).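

Chloro in place of methoxy, on an aromatic carbon meta to a large group, is the first exchange of the methoxy itself, and in this assay it gives a 1.4-fold higher number from compound 2 to compound 3 (0.13 log units; within the scatter) and so stays within the scatter. 3-Chlorophenyl in place of 4-methoxyphenyl gives a 1.2-fold higher number from compound 1 to compound 3 (0.09 log units; within the scatter) and likewise stays within the scatter, so the three compounds do not separate in this assay. No evidence bears on the reason for this result. Still open, on these data alone, is whether an amine or a carboxylic acid at this position would give a step beyond the scatter.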